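Swapping the Acyl Group on Compound 3

The source may report more compounds than this note shows. Statements on the series, on what has been measured and on what is new or still open speak of the compounds shown alone.

Of the compounds shown here, three sharing one core have been tested in a functional assay on NCI-H1975 cells (Homo sapiens) for inhibition, read by sulforhodamine B assay, tested at 10 uM; on this read-out higher numbers stand for more inhibition at the one concentration tested (going by the name of the read-out) and lower numbers for less inhibition. Compound 1 `CN1CCN(c2ccc(C3=NN(C(=O)CCCl)C(c4ccc(N(C)C)cc4)C3)cc2)CC1` gives -0.2%. Compound 2 `CN1CCN(c2ccc(C3=NN(C(=O)c4ccc(C(F)(F)F)cc4)C(c4ccc(N(C)C)cc4)C3)cc2)CC1` gives 93.2%. Compound 3 `CN(C)c1ccc(C2CC(c3ccc(-n4ccnc4)cc3)=NN2C(=O)CCCl)cc1` gives -2.5%, the lowest of the three numbers; its gap to compound 1 lies within the scatter, while compound 2 sits far above it.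

Compound 4 `CN(C)c1ccc(C2CC(c3ccc(-n4ccnc4)cc3)=NN2C(=O)c2ccc(C(F)(F)F)cc2)cc1` is not yet measured. It differs from compound 3 in one place: 4-(trifluoromethyl)phenyl in place of 2-chloroethyl on a carbonyl carbon.

The same change has been seen once already: a number 93.4 percentage points higher from compound 1 to compound 2 (beyond the scatter). The other known step, a number 2.3 percentage points lower from compound 1 to compound 3 (within the scatter), stayed within the scatter. Compound 4 is therefore expected to show a large gain, a number 90.5 percentage points higher from compound 3 to compound 4 (beyond the scatter), landing near an estimated 88%, with a range from 65% to 99%.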

Compound 4, a percentage reported as inhibition, at one concentration (the size of the read-out at that concentration, not a potency): 15.9%
The estimate for compound 4 lay 72.1 percentage points above the measured number; the measured number lies below the stated range.
By their numbers in this assay, from the lowest: compounds 3 and 1 (each within the scatter of the next); then compound 4; then compound 2.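

On the compounds carrying 1H-imidazol-1-yl, 4-(trifluoromethyl)phenyl in place of 2-chloroethyl yields only a number 18.4 percentage points higher from compound 3 to compound 4 (beyond the scatter), so this change has no fixed size: what it adds depends on the other group. Likewise, 1H-imidazol-1-yl in place of 4-methylpiperazin-1-yl stayed within the scatter with 2-chloroethyl, yet gives a number 77.3 percentage points lower from compound 2 to compound 4 (beyond the scatter) with 4-(trifluoromethyl)phenyl present.

These compounds do not tell why the two changes depend on each other. From the compounds shown here alone, it also remains open whether the same dependence holds for other groups on the carbonyl carbon, such as an unsubstituted phenyl or a longer chain ending in an amine.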